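A few compounds are considered here, and "the series" means these few. Any claim that something is new, unique, unknown or untested is made for them only; others in the source may bear on it.

Measured compounds:
compound 1, `CCCN(CC[C@H]1CC[C@H](NC(=O)/C=C/c2ccccc2Cl)CC1)[C@H]1CCc2nc(N)sc2C1`, in an assay on brain for displacement of a labelled ligand from D(3) dopamine receptor (Rattus norvegicus) (a higher number here means a weaker inhibitor, a lower number a stronger inhibitor), gives 1.2 nM
compound 2, `CCCN(CC[C@H]1CC[C@H](NC(=O)c2ccc3ccccc3n2)CC1)[C@H]1CCc2nc(N)sc2C1`, in this assay gives 1.6 nM

Among these two numbers compound 2 holds the higher one, yet its nearest neighbour is compound 1, and the step of a 1.3-fold higher number from compound 1 to compound 2 (0.12 log units; within the scatter) lies within the scatter, so nothing separates the two in order of potency. Both share the same core and differ only in the group on the carbonyl carbon, where quinolin-2-yl replaces 2-(2-chlorophenyl)ethenyl.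

Compound 3, `CCCN(CC[C@H]1CC[C@H](NC(=O)c2ccc(-n3cncn3)cc2)CC1)[C@H]1CCc2nc(N)sc2C1`, has not yet been measured in this assay. It differs from compound 2 in the same place: 4-(1H-1,2,4-triazol-1-yl)phenyl in place of quinolin-2-yl on a carbonyl carbon. For the measured compounds named here, the one measured step that bears on this change is a 1.3-fold higher number from compound 1 to compound 2 (0.12 log units; within the scatter), which shows that exchanging the group on the carbonyl carbon for a different aromatic group left the number essentially unmoved. On that basis the expected step of a 1.6-fold higher number from compound 2 to compound 3 (0.19 log units; within the scatter) is small and not beyond the scatter. Compound 3 is therefore estimated at 2.5 nM in this assay, with a likely range from 0.8 nM to 8 nM.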

Compound 3, inhibition constant: 2.4 nM
Estimate against measurement, compound 3: 1.0-fold (0.02 log units) above; the range from low to high includes it.
By their numbers in this assay, from the lowest: compounds 1, 2 and 3 (each within the scatter of the next).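

In this assay, the carbonyl carbon whose other neighbour is the amide-type nitrogen now carries a third group, and the new group differs from quinolin-2-yl in more than its outline: 4-(1H-1,2,4-triazol-1-yl)phenyl brings a five-membered aromatic ring with 3 hetero atoms and 3 hydrogen-bond acceptors where quinolin-2-yl has 1, yet the result is a 1.5-fold higher number from compound 2 to compound 3 (0.18 log units; within the scatter). The comparison with the open-chain group, a 2.0-fold higher number from compound 1 to compound 3 (0.30 log units; within the scatter), also stays within the scatter, so the three groups, which share only an aromatic ring and the link to the carbonyl carbon, cannot be put in any order at this position, and the change in ring type and acceptor count shows no measurable effect on the number here. Nothing measured in this account explains why these exchanges leave the number where it is.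

Going by these compounds, all three groups carry an aromatic ring, so it remains open whether a group without one, such as a saturated alkyl chain, a primary amine or a carboxylic acid, would give a step beyond the scatter at this carbonyl carbon. It also remains open how these same exchanges read at any receptor other than the one in this assay, since only this read-out is shown.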